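The source may report more compounds than this note shows. Statements on the series, on what has been measured and on what is new or still open speak of the compounds shown alone.

Compounds and values in a functional assay on the whole organism (strain Sprague-Dawley) for inhibition, with Rattus norvegicus as the target, with a stated time of 10 min; on this read-out lower numbers stand for an effect already at smaller amounts and higher numbers for an effect only at larger amounts of compound:

Compound 1, `O=C(O)c1cnc(-c2ccccc2Cl)[nH]c1=O`: 5 mg/kg
Compound 2, `COc1ccccc1-c1ncc(C(=O)O)c(=O)[nH]1`: 10 mg/kg
Compound 3, `CCOc1ccc(Cl)cc1-c1ncc(C(=O)O)c(=O)[nH]1`: 0.5 mg/kg

Compound 1 and compound 2 are linked by one change, (methoxy in place of chloro on an aromatic carbon), and the step is a 2.0-fold higher number from compound 1 to compound 2 (0.30 log units; within the scatter). Compound 3 stands apart from both; the difference between its core and the core of compound 1 is not broken down here. In this assay compound 3 gives the lowest of the three numbers, and its gaps to compound 1 and to compound 2 both lie beyond the scatter.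

Compound 4, `CCOc1ccc(OC)cc1-c1ncc(C(=O)O)c(=O)[nH]1`, has not yet been measured. It differs from compound 3 by methoxy in place of chloro on an aromatic carbon. This is the same kind of change as that from compound 1 to compound 2, though the surroundings differ: in the earlier pair the change sits ortho to a large group, whereas in compound 4 it sits meta to a large group and para to an ethoxy group. Because the earlier step was a 2.0-fold higher number from compound 1 to compound 2 (0.30 log units; within the scatter), compound 4 is expected to move from compound 3 by about a 2.0-fold higher number from compound 3 to compound 4 (0.30 log units; within the scatter). Compound 4 is therefore estimated at 1 mg/kg, with a range of 0.3 mg/kg to 3 mg/kg.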

Compound 4, dose for 50% inhibition: 0.2 mg/kg
Compound 4: middle estimate off by 5.0-fold (0.70 log units), on the high side; measured number below the stated range.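

On the core of compound 3, methoxy in place of chloro on an aromatic carbon gives a 2.5-fold lower number from compound 3 to compound 4 (0.40 log units; beyond the scatter) in this assay. Set beside the earlier pair, the same change does not carry over from one core to the other as a fixed step: the same change on two cores in this assay, a 2.0-fold higher number (0.30 log units; within the scatter) from compound 1 to compound 2 and a 2.5-fold lower number (0.40 log units; beyond the scatter) from compound 3 to compound 4, 5.0-fold (0.70 log units) apart, beyond the scatter of two such steps. Going by these compounds alone, only two pairs stand behind this, and they differ in the core as well as in where the change sits; the data do not show which of these differences matters, or how the change would run on a further core.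

The compounds shown leave open how an amine, a hydroxyl or a fluoro group would compare with chloro and methoxy at this place on the core of compound 3. Also open, as far as these compounds go, is how a longer chain in place of the ethoxy group, or an amide in place of the carboxylic acid, would read in this assay.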